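A silicon-bearing group replaces 4-methylpiperazin-1-yl in compound 3

This account rests on a few compounds, and the source may have more. Where it says the series, first, only, none or still open, it means among the compounds named here.

In a functional assay on SMMC-7721 cells (Homo sapiens) for antiproliferative activity, read by MTT assay, with a stated time of 48 h (a higher number here means a weaker inhibitor, a lower number a stronger inhibitor), compound 3 `CC(C)=CCC[C@]1(C)/C=C/[C@@H](OC(=O)C=C(C)C)[C@](C)(O)/C=C/C(=O)/C(CN2CCN(C)CC2)=C\C1` gives 2940 nM, the middle of three numbers, with compound 2 `CC(C)=CCC[C@]1(C)/C=C/[C@@H](OC(=O)C=C(C)C)[C@](C)(O)/C=C/C(=O)/C(CN(C)C)=C\C1` at 820 nM and compound 1 `COC/C1=C/C[C@](C)(CCC=C(C)C)/C=C/[C@@H](OC(=O)C=C(C)C)[C@](C)(O)/C=C/C1=O` at 11000 nM. Compound 4 `CC(C)=CCC[C@]1(C)/C=C/[C@@H](OC(=O)C=C(C)C)[C@](C)(O)/C=C/C(=O)/C(C[Si](C)(C)C(C)(C)C)=C\C1` differs from compound 3 by one change: a group of 7 heavy atoms (6 carbon, 1 silicon; no ring) in place of a group of 7 heavy atoms (5 carbon, 2 nitrogen; one six-membered non-aromatic ring with 2 hetero atoms), on a saturated chain carbon bound to a double-bonded ring carbon. Three measured steps at this carbon bear on it: a 13-fold lower number from compound 1 to compound 2 (1.13 log units; beyond the scatter), a 3.7-fold lower number from compound 1 to compound 3 (0.57 log units; beyond the scatter) and a 3.6-fold higher number from compound 2 to compound 3 (0.55 log units; beyond the scatter). Compound 4 keeps neither dimethylamino nor 4-methylpiperazin-1-yl, the two groups that gave lower numbers than methoxy, and its entering group has not been measured in this series. A modest move toward compound 1 is therefore expected, with the estimated step of a 2.2-fold higher number from compound 3 to compound 4 (0.34 log units; beyond the scatter). The estimate for compound 4 is 6500 nM, with an expected range of 1800 nM to 22000 nM.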

Compound 4, half-maximal inhibitory concentration: 4000 nM
Estimate against measurement, compound 4: 1.6-fold (0.21 log units) above; measured number inside the range.
By their numbers in this assay, from the lowest: compound 2; then compounds 3 and 4 (each within the scatter of the next); then compound 1.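

At this saturated chain carbon, the silicon-bearing group and 4-methylpiperazin-1-yl read alike in this assay, with a 1.4-fold higher number from compound 3 to compound 4 (0.13 log units; within the scatter). A group without nitrogen can therefore still give a lower number than methoxy, with a 2.8-fold lower number from compound 1 to compound 4 (0.44 log units; beyond the scatter), although dimethylamino remains ahead, with a 4.9-fold higher number from compound 2 to compound 4 (0.69 log units; beyond the scatter). No measurement shown here accounts for these differences. The compounds shown leave open how a primary amine or a carboxylic acid would read at this carbon, and whether trimethylsilyl would come closer to dimethylamino.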